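The source may report more compounds than this note shows. Statements on the series, on what has been measured and on what is new or still open speak of the compounds shown alone.

Measured compounds:
- compound 1, `COC(=O)CCCCCOc1cc(-c2ccccc2)cc(-c2ccccc2)n1`: 1000 nM
- compound 2, `O=C(O)CCCCCOc1cc(-c2ccccc2)cc(-c2ccc(F)cc2)n1`: > 10000 nM
- compound 3, `CC(CCCCOc1cc(-c2ccccc2)cc(-c2ccccc2F)n1)C(=O)O`: 70 nM

In a functional assay on cells for inhibition of leukotriene B4 receptor 1 (Homo sapiens) (a lower number here means a stronger inhibitor, a higher number a weaker inhibitor), compound 2 gives > 10000 nM, which is a limit of the assay rather than a number. For the measured compounds named here, compound 2 is the one value that sits at the limit of > 10000 nM in this assay, at which 1 of the 3 values shown sits. The other two compounds give numbers: compound 1 gives 1000 nM in this assay, and compound 3 gives 70 nM. Compound 2 therefore stands at the weak end of what has been measured here, and its true value is not known.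

Compound 4, `O=C(O)CCCCCOc1cc(-c2ccccc2)cc(-c2ccccc2)n1`, has not yet been measured. It differs from compound 2 by one change: hydrogen in place of fluoro on an aromatic carbon, in words, hydrogen in place of fluoro on an aromatic carbon. Going by the values given here, no step between two measured compounds covers this change, so its size cannot be read from the data. Compound 4 is expected to land somewhere between the limit of compound 2 and the value of compound 1, with a step from compound 2 to compound 4 estimated as an at least 3.3-fold lower number from compound 2 to compound 4 (0.52 log units; beyond the scatter) and wide uncertainty. The estimate for compound 4 in this assay is 3000 nM, within a range from 500 nM to 15000 nM.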

Compound 4, half-maximal inhibitory concentration: 2000 nM
Beside the measured number, compound 4's estimate is 1.5-fold (0.18 log units) above it; measured number inside the range.
By their numbers in this assay, from the lowest: compound 3; then compounds 1 and 4 (each within the scatter of the next). At a limit, above all of these: compound 2.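

Taking away the fluoro, which sits on an aromatic carbon para to a large group, gives an at least 5.0-fold lower number from compound 2 to compound 4 (0.69 log units; beyond the scatter) in this assay, so the change from 4-fluorophenyl to phenyl is the first single change here with a step beyond the scatter. From the compounds shown here alone, compound 2 stands at a limit of the assay rather than at a number, so the full size of this step stays unknown: the limit of > 10000 nM in this assay, at which 1 of the 4 values shown sits. Putting hydrogen in place of methyl on the oxygen next to the carbonyl group gives a 2.0-fold higher number from compound 1 to compound 4 (0.30 log units; within the scatter), so in this assay the ester and the carboxylic acid cannot be told apart on the phenyl compounds.

Going by these compounds, whether a chlorine or a methoxy group at this same place would behave like fluoro or like hydrogen remains open. Compound 3 differs from these compounds in more than one place, so its value cannot be tied to any single change.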